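The source may hold more compounds than are shown below. What is called first, only, known or untested is meant among the compounds shown, and "the series" means these compounds.

Compound 1 `C=CS(=O)(=O)N1CCN(c2ncnc3sc(-c4ccccc4)cc23)CC1`: 54200 nM
Compound 2 `C=CS(=O)(=O)N1CCN(c2ncnc3sc(-c4cccc5ncccc45)cc23)CC1`: 21000 nM
Compound 3 `C=CS(=O)(=O)N1CCN(c2ncnc3sc(-c4ccc(F)nc4)cc23)CC1`: 16000 nM

All three were compared in a functional assay on MDA-MB-231 cells (Homo sapiens) for antiproliferative activity, read by MTT assay, with a stated time of 48 h; a higher number here means a weaker inhibitor, a lower number a stronger inhibitor. Compound 1 has the highest number of the three, and the other two lie beyond the scatter from it: the steps were a 2.6-fold lower number from compound 1 to compound 2 (0.41 log units; beyond the scatter) and a 3.4-fold lower number from compound 1 to compound 3 (0.53 log units; beyond the scatter). Between the two heteroaryl compounds the gap is only a 1.3-fold lower number from compound 2 to compound 3 (0.12 log units; within the scatter). Compound 4 `C=CS(=O)(=O)N1CCN(c2ncnc3sc(-c4c(C)noc4C)cc23)CC1` keeps the shared core and alters the same position: 3,5-dimethyl-1,2-oxazol-4-yl in place of phenyl on an aromatic carbon. Both measured replacements at this position, quinolin-5-yl and 6-fluoropyridin-3-yl, gave a modest lower number, so a similar modest lower number is expected for compound 4, a step of a 2.2-fold lower number from compound 1 to compound 4 (0.34 log units; beyond the scatter). Compound 4 is therefore estimated at 25000 nM, within a range from 9000 nM to 70000 nM.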

Compound 4, half-maximal inhibitory concentration: 28200 nM
Beside the measured number, compound 4's estimate is 1.1-fold (0.05 log units) below it; measured number inside the range.
By their numbers in this assay, from the lowest: compounds 3, 2, 4 and 1 (each within the scatter of the next, the first and the last beyond it).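

In this assay, among these compounds, the 3,5-dimethyl-1,2-oxazol-4-yl group is the first replacement of phenyl at this place whose step stays within the scatter (a 1.9-fold lower number from compound 1 to compound 4 (0.28 log units; within the scatter)). Compound 4 also cannot be separated from the two other replacements (a 1.8-fold higher number from compound 3 to compound 4 (0.25 log units; within the scatter)) and (a 1.3-fold higher number from compound 2 to compound 4 (0.13 log units; within the scatter)), so this five-membered aromatic ring leaves it between groups that the data do not distinguish from it. No evidence on hand accounts for this result. Going by these compounds, whether an amine or a carboxylic acid at this place would shift the number further remains open.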